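The source may hold more compounds than are shown below. What is called first, only, known or untested is meant among the compounds shown, and "the series" means these compounds.

Compound 1 `COc1cc(NC(C)CCCNC(=O)NNC(=O)NCCO)c2ncccc2c1` is the starting point of this account. Within the data shown here, in a physicochemical assay for inhibition, read by spectrophotometry, tested at 100 uM (on this read-out lower numbers stand for less inhibition and higher numbers for more inhibition at the one concentration tested (going by the name of the read-out)), compound 1 gives 27%, the lowest of the two numbers measured so far. Among the measured compounds shown here, the only other measured compound, compound 2 `COc1cc(NC(C)CCCNC(=O)N(C)C(c2ccccc2)c2ccccc2)c2ncccc2c1`, gives 79% in this assay, a number well beyond the scatter above compound 1. For the measured compounds named here, no step between two measured compounds that differ in a single place has been recorded, so the comparison rests on these two values alone.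

The unmeasured compound 3 `COc1cc(NC(C)CCCNC(=O)Nc2ccc(Cl)c(C(F)(F)F)c2)c2ncccc2c1` differs from compound 1 in one place: 4-chloro-3-(trifluoromethyl)phenyl in place of ((2-hydroxyethyl)carbamoyl)amino on an amide-type nitrogen. The group that leaves carries hydrogen-bond donors and acceptors and no ring, while the group that enters is a single aromatic ring carrying chlorine and trifluoromethyl, with no donors or acceptors.

Going by the values given here, since compound 2, the only compound with a sizeable reading of 79%, also lacks such a donor-rich tail, compound 3 is expected to move upward in this assay, with a step of a number 41 percentage points higher from compound 1 to compound 3 (beyond the scatter) estimated to reach beyond the scatter. Compound 3 is therefore estimated at 68%, within a range from 42% to 90%.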

Compound 3, a percentage reported as inhibition, at one concentration (the size of the read-out at that concentration, not a potency): 61%
Compound 3: the middle estimate sits 7 percentage points above what was measured; the range from low to high includes it.
By their numbers in this assay, from the lowest: compound 1; then compound 3; then compound 2.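

On the amide-type nitrogen whose other neighbour is the carbonyl carbon, putting 4-chloro-3-(trifluoromethyl)phenyl in place of ((2-hydroxyethyl)carbamoyl)amino gives in this assay a clear change: a number 34 percentage points higher from compound 1 to compound 3 (beyond the scatter) for this one replacement. Among these compounds, this is the only single-place change on record here, and it shows that this position alone can move the reading beyond the scatter while the shared core stays the same. The step cannot be divided among its parts, as the replacement adds a six-membered aromatic ring, chlorine and trifluoromethyl and removes the hydrogen-bond donors and acceptors of the leaving group all at once, and no measurement bears on why the reading rises.

The compounds shown leave open whether the ring alone accounts for the step or its chlorine and trifluoromethyl contribute, which an unsubstituted phenyl on the same nitrogen would help to settle. They also leave open how this assay would respond to a shorter tail, such as a plain 2-hydroxyethyl chain, or to a carboxylic acid at this place.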